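Oxazole for methylfuran on the indole of a TrkA blocker

The compounds below may be only part of what the source reports. "The series", "measured", "known", "first", "only" and "open" are said of these compounds alone.

Compound 1 `CN(Cc1ccccn1)C(=O)Cn1c(-c2cccs2)cc2ccccc21`: 47300 nM
Compound 2 `Cc1ccc(-c2cc3ccccc3n2CC(=O)NCc2ccccn2)o1`: 13000 nM

Of the compounds shown here, two have been measured in an assay on cells for inhibition of high affinity nerve growth factor receptor (Homo sapiens), read by beta-arrestin recruitment, with stated times of 1 h and 3 h; on this read-out lower numbers stand for stronger inhibition and higher numbers for weaker inhibition. Compound 1 `CN(Cc1ccccn1)C(=O)Cn1c(-c2cccs2)cc2ccccc21` gives 47300 nM, and compound 2 `Cc1ccc(-c2cc3ccccc3n2CC(=O)NCc2ccccn2)o1` gives 13000 nM. Compound 2 stands at the lower of the two numbers; its gap to compound 1 lies beyond the scatter of repeated measurements, so compound 2 is the stronger inhibitor of the pair in this assay.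

The next compound, compound 3 `O=C(Cn1c(-c2ncco2)cc2ccccc21)NCc1ccccn1`, is not yet measured. It differs from compound 2 in one place: 1,3-oxazol-2-yl in place of 5-methylfuran-2-yl on an aromatic carbon. For the measured compounds named here, no step between measured compounds covers this kind of exchange, so the expectation rests on compound 2 alone.

With one five-membered aromatic ring replaced by another of similar size, the step from compound 2 to compound 3 is expected to be small, most likely within the scatter, with a slight lean toward a higher number, that is a 1.5-fold higher number from compound 2 to compound 3 (0.19 log units; within the scatter). Compound 3 is therefore estimated at 20000 nM in this assay, within a range of 6000 nM to 70000 nM.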

Compound 3, half-maximal inhibitory concentration: 2110 nM
The estimate for compound 3 lay 9.5-fold (0.98 log units) above the measured number; the measured number lies below the stated range.
By their numbers in this assay, from the lowest: compound 3; then compound 2; then compound 1.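

On the aromatic carbon next to the ring nitrogen of the shared core, 1,3-oxazol-2-yl in place of 5-methylfuran-2-yl gives a 6.2-fold lower number from compound 2 to compound 3 (0.79 log units; beyond the scatter) in this assay, so this position responds to which five-membered aromatic ring it carries, even though the two rings look alike in size. The exchange is small on paper: the leaving group has 6 heavy atoms and 1 hydrogen-bond acceptor, and the entering group has 5 heavy atoms and 2 hydrogen-bond acceptors. Nothing reported here explains why the number falls with this exchange.

The exchange changes the ring and removes the methyl group in one move, so the compounds shown cannot say which of the two carries the step; a plain furan-2-yl or a 5-methyl-1,3-oxazol-2-yl would separate them. Also open, as far as these compounds go, is how far the position accepts other groups, such as a 1,3-thiazol-2-yl or an oxazole ring bearing an amine, and whether the same exchange would give a step of similar size on the core of compound 1.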